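A few compounds are considered here, and "the series" means these few. Any claim that something is new, unique, unknown or untested is made for them only; others in the source may bear on it.

Working notes on the series. In a functional assay on CCRF-CEM cells for antagonist activity at C-X-C chemokine receptor type 4 (Homo sapiens), read by calcium flux, with stated times of 25 min and 90 s (a lower number here means a stronger inhibitor, a higher number a weaker inhibitor), compound 3 `CN(C[C@H]1Cc2c(cccc2N2CCNCC2)CN1)[C@H]1CCCc2cccnc21` gives 6.08 nM, the lowest number of the three measured compounds. Compound 1 `c1cnc2c(c1)CCC[C@@H]2N(CC1CC1)C[C@H]1Cc2c(cccc2N2CCNCC2)CN1` gives 26.7 nM and compound 2 `c1cnc2c(c1)CCC[C@@H]2N(CC1CCCCC1)C[C@H]1Cc2c(cccc2N2CCNCC2)CN1` gives 715 nM. The measured steps all change the group carried on the amine nitrogen: a 4.4-fold lower number from compound 1 to compound 3 (0.64 log units; beyond the scatter), a 27-fold higher number from compound 1 to compound 2 (1.43 log units; beyond the scatter) and a 120-fold lower number from compound 2 to compound 3 (2.07 log units; beyond the scatter). Across these three compounds the number rises each time the group on that nitrogen becomes larger, the cyclohexyl step being the largest.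

Compound 4 `CC(C)N(C[C@H]1Cc2c(cccc2N2CCNCC2)CN1)[C@H]1CCCc2cccnc21` differs from compound 3 by isopropyl in place of methyl on an amine nitrogen. Isopropyl is larger than methyl but smaller than the cyclopropylmethyl and cyclohexylmethyl groups of compound 1 and compound 2, so the expectation is a rise beyond the scatter but smaller than the step seen from compound 3 to compound 1 in reverse. For compound 4 the expected step is a 2.5-fold higher number from compound 3 to compound 4 (0.39 log units; beyond the scatter) in this assay. Compound 4 is therefore estimated at 15 nM, with a range from 6 nM to 50 nM.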

Compound 4, half-maximal inhibitory concentration: 364 nM
Estimate against measurement, compound 4: 24-fold (1.39 log units) below, outside the stated range (above it).
By their numbers in this assay, from the lowest: compound 3; then compound 1; then compounds 4 and 2 (each within the scatter of the next).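

Within the data shown here, on the amine nitrogen, isopropyl in place of methyl gives a 60-fold higher number from compound 3 to compound 4 (1.78 log units; beyond the scatter) in this assay, so this position tolerates much less than the earlier compounds suggested, and the rise with group size seen across compounds 3, 1 and 2 does not hold for compound 4. Compound 4 goes against that pattern: isopropyl in place of cyclopropylmethyl gives a 14-fold higher number from compound 1 to compound 4 (1.13 log units; beyond the scatter), although isopropyl is the smaller group, while isopropyl in place of cyclohexylmethyl gives a 2.0-fold lower number from compound 2 to compound 4 (0.29 log units; within the scatter), so those two groups cannot be told apart here. No available measurement accounts for this behaviour of isopropyl.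

From the compounds shown here alone, it remains open where between methyl and isopropyl the rise sets in, as an ethyl group on this nitrogen would show. Also open, going by these compounds, is whether an unbranched propyl chain there would behave like isopropyl or like cyclopropylmethyl.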